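Swapping a Pyridine Ring for a Trifluoromethylphenyl Ring

The source may report more compounds than this note shows. Statements on the series, on what has been measured and on what is new or still open speak of the compounds shown alone.

Of the compounds shown here, three sharing one core have been tested in a functional assay on BJAB cells (Homo sapiens) for antiproliferative activity, with a stated time of 4 days; on this read-out higher numbers stand for an effect only at larger amounts of compound and lower numbers for an effect already at smaller amounts. Compound 1 `COc1ccc(-c2c(C)nn(-c3nc(-c4ccc(Cl)c(Cl)c4)c(SC(C)C)s3)c2C(=O)O)cc1` gives 2100 nM. Compound 2 `Cc1ccc(-c2c(C)nn(-c3nc(-c4ccc(Cl)c(Cl)c4)c(SC(C)C)s3)c2C(=O)O)cc1` gives 3800 nM. Compound 3 `Cc1nn(-c2nc(-c3ccc(Cl)c(Cl)c3)c(SC(C)C)s2)c(C(=O)O)c1-c1ccncc1` gives 5900 nM, the highest of the three numbers; the step of a 2.8-fold higher number from compound 1 to compound 3 (0.45 log units; beyond the scatter) lies beyond the scatter, while the step of a 1.6-fold higher number from compound 2 to compound 3 (0.19 log units; within the scatter) lies within it.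

Compound 4 `Cc1nn(-c2nc(-c3ccc(Cl)c(Cl)c3)c(SC(C)C)s2)c(C(=O)O)c1-c1ccccc1C(F)(F)F` has not yet been measured. It differs from compound 3 in one place: 2-(trifluoromethyl)phenyl in place of pyridin-4-yl on an aromatic carbon

For the measured compounds named here, two measured steps bear on this change, since both put pyridin-4-yl in place of a carbon-only ring on the same aromatic carbon: a 2.8-fold higher number from compound 1 to compound 3 (0.45 log units; beyond the scatter) and a 1.6-fold higher number from compound 2 to compound 3 (0.19 log units; within the scatter). Both point the same way, a higher number when pyridin-4-yl enters, so its departure in favour of a carbon-only ring should bring a modestly lower number. Going by the values given here, no measured compound carries a trifluoromethyl group, so what that part of the change contributes is unknown, and the range must stay wide. The expected step of a 2.0-fold lower number from compound 3 to compound 4 (0.29 log units; within the scatter) is therefore modest and downward. Compound 4 is estimated at 3000 nM in this assay, with a range from 1200 nM to 8000 nM.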

Compound 4, half-maximal effective concentration: 5200 nM
Compound 4: middle estimate off by 1.7-fold (0.24 log units), on the low side; measured number inside the range.
By their numbers in this assay, from the lowest: compounds 1, 2, 4 and 3 (each within the scatter of the next, the first and the last beyond it).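

In this assay, the step (a 1.1-fold lower number from compound 3 to compound 4 (0.05 log units; within the scatter)) shows that this position accepts a much larger group, and one without the hydrogen-bond acceptor of pyridin-4-yl, with no change beyond the scatter. The step to the 4-methylphenyl compound (a 1.4-fold higher number from compound 2 to compound 4 (0.14 log units; within the scatter)) also stays within the scatter, while the step from the 4-methoxyphenyl compound (a 2.5-fold higher number from compound 1 to compound 4 (0.39 log units; beyond the scatter)) lies beyond it, so 2-(trifluoromethyl)phenyl and pyridin-4-yl now both stand apart from 4-methoxyphenyl, although neither stands apart from 4-methylphenyl. No measurement at hand explains why such different rings give readings this close.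

From the compounds shown here alone, what the trifluoromethyl group contributes on its own stays open, and a plain phenyl ring at this carbon would be the direct comparison for compound 4. Going by these compounds, it is also open whether an aromatic ring is needed here at all, a question that a saturated ring such as cyclohexyl or a ring carrying an amine could address.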